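Cyclopentyl for isopropyl on the ketone side chain

The source may hold more compounds than are shown below. What is called first, only, known or untested is meant among the compounds shown, and "the series" means these compounds.

Of the compounds shown here, three have been measured in an assay on HEK293 cells for positive allosteric modulation of metabotropic glutamate receptor 3 (Rattus norvegicus), read by thallium flux, with a stated time of 2.5 min; on this read-out lower numbers stand for smaller maximal responses and higher numbers for larger maximal responses. Compound 1 `Cc1c(OCCCCOc2ccccc2C(=O)O)ccc(C(=O)CC2CCCC2)c1O` gives 32.9%, compound 2 `Cc1c(OCCCCOc2cccc(C(=O)O)c2)ccc(C(=O)CC2CCCC2)c1O` gives 92.9%, and compound 3 `Cc1cc(OCCCCOc2ccc(C(=O)CC(C)C)c(O)c2C)ccc1C(=O)O` gives 41.9%. Compound 3 stands second highest of the three; its nearest neighbour is compound 1, whose value lies within the scatter of compound 3, while compound 2 lies far above it. For the measured compounds named here, the only single-place step known so far, a number 60 percentage points higher from compound 1 to compound 2 (beyond the scatter), concerns the carboxyphenyl and says nothing about the alkyl group on the carbonyl side.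

Compound 4 `Cc1cc(OCCCCOc2ccc(C(=O)CC3CCCC3)c(O)c2C)ccc1C(=O)O` differs from compound 3 in one place: cyclopentyl in place of isopropyl on a saturated chain carbon bound to a carbonyl carbon. Going by the values given here, compounds 1 and 2 already carry the cyclopentyl, but each differs from compound 3 in more than one place, so no measured step bears directly on this change. With no comparison to lean on, no step beyond the scatter is expected, a number 3.1 percentage points higher from compound 3 to compound 4 (within the scatter). Compound 4 is therefore estimated at 45%, with a range from 25% to 70%.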

Compound 4, largest response reached (reported as percent of maximum), in percent of the reference or control that the assay uses: 23.7%
Compound 4: the middle estimate sits 21.3 percentage points above what was measured; measured number outside the range, below it.
By their numbers in this assay, from the lowest: compounds 4, 1 and 3 (each within the scatter of the next, the first and the last beyond it); then compound 2.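

Working notes: the alkyl group on the ketone side chain matters in this assay, as cyclopentyl in place of isopropyl on a saturated chain carbon bound to a carbonyl carbon gives a measurable loss (a number 18.2 percentage points lower from compound 3 to compound 4 (beyond the scatter)). With cyclopentyl held fixed, the carboxyphenyl comparison gains a third member: 4-carboxy-3-methylphenyl falls far short of 3-carboxyphenyl (a number 69.2 percentage points lower from compound 2 to compound 4 (beyond the scatter)) but cannot be separated from 2-carboxyphenyl (a number 9.2 percentage points lower from compound 1 to compound 4 (within the scatter)). No measurement at hand explains the loss on going to cyclopentyl.

Still open, from the compounds shown here alone, is whether the isopropyl-to-cyclopentyl step takes the same direction and size when 3-carboxyphenyl is the aryl group. Going by these compounds, the response with a cyclohexyl or a tert-butyl group at this chain carbon also remains open.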